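Swapping Bromo for Fluoro in a Mouse Test

The source may hold more compounds than are shown below. What is called first, only, known or untested is meant among the compounds shown, and "the series" means these compounds.

Compound 1 `CN(C)C(=O)Cn1c(-c2cccc(Cl)c2)nc2cccnc21`: > 56.2 mg/kg; < 100 mg/kg (2 entries)
Compound 2 `CN(C)C(=O)Cn1c(-c2ccc(Br)cc2)nc2cccnc21`: 7 mg/kg

Within the data shown here, in a functional assay on the whole organism with Mus musculus as the target (a lower number here means that less compound is needed, a higher number that more compound is needed for the effect), compound 2 gives 7 mg/kg, the only single number so far. For compound 1, > 56.2 mg/kg; < 100 mg/kg (2 entries) is a limit of the assay, not a number. Compound 3 `CN(C)C(=O)Cn1c(-c2ccc(F)cc2)nc2cccnc21` carries one change from compound 2: fluoro in place of bromo on an aromatic carbon. Among the measured compounds shown here, no measured step shows what such a swap does, so only a modest rise in the dose needed in this assay is expected. The expected change is a 1.7-fold higher number from compound 2 to compound 3 (0.23 log units; within the scatter). For compound 3 the estimated dose is 12 mg/kg, with an expected range of 4 mg/kg to 40 mg/kg.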

Compound 3, dose for half-maximal effect: 40.5 mg/kg
Beside the measured number, compound 3's estimate is 3.4-fold (0.53 log units) below it; measured number outside the range, above it.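

In this assay, replacing 4-bromophenyl with 4-fluorophenyl gives a 5.8-fold higher number from compound 2 to compound 3 (0.76 log units; beyond the scatter). Among these compounds, this is the first measured step at this position, and it shows that the two halogens are not interchangeable here: the mouse dose depends on which one sits on this aromatic carbon. Nothing measured here explains why the dose shifts. On these data alone, it remains open whether a methoxy group, a nitrile or an amine at this position would stay close to compound 2 or move further away. Compound 1 differs from compound 2 in more than one place, so it cannot settle this.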